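Swapping Trifluoromethyl for Carbamoyl: Solubility Still Open

A few compounds are considered here, and "the series" means these few. Any claim that something is new, unique, unknown or untested is made for them only; others in the source may bear on it.

compound 1 `COc1ccc(Nc2cc3[nH]c(-c4cccc(C(F)(F)F)c4)nc3cn2)nc1`: < 5000 nM
compound 2 `Fc1ccc(Nc2cc3[nH]c(-c4cccc(C(F)(F)F)c4)nc3cn2)nc1`: < 5000 nM
compound 3 `FC(F)(F)c1ccc(Nc2cc3[nH]c(-c4cccc(C(F)(F)F)c4)nc3cn2)nc1`: < 5000 nM

The three measured compounds share one core and differ only in the group on the six-membered aromatic ring with one nitrogen. In a physicochemical assay for solubility, using the shake flask method, in phosphate buffer, measured as kinetic solubility, with a stated time of 20 h, at pH 6.5 (a lower number here means a less soluble compound, a higher number a more soluble compound), compound 1 gives < 5000 nM, which is a limit of the assay rather than a number. Compound 2 gives < 5000 nM, again a limit. Compound 3 gives < 5000 nM, also a limit. Because every value sits at the limit of < 5000 nM in this assay, at which 3 of the 3 values shown sit, the steps a step that the two limits leave unreadable from compound 1 to compound 2, a step that the two limits leave unreadable from compound 1 to compound 3 and a step that the two limits leave unreadable from compound 2 to compound 3 cannot be read in size or in direction, and compound 3 stands where all three stand, at the limit.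

Compound 4 `NC(=O)c1ccc(Nc2cc3[nH]c(-c4cccc(C(F)(F)F)c4)nc3cn2)nc1` has not yet been measured. It differs from compound 3 by carbamoyl in place of trifluoromethyl on an aromatic carbon. For the measured compounds named here, none of the measured steps bears on this change, as no measured compound carries a carbamoyl group and all three steps are unreadable. Compound 4 is therefore expected, with wide uncertainty, to give 8000 nM in this assay, within 2000 nM to 40000 nM. Going by the values given here, the estimated step is an at least 1.6-fold higher number from compound 3 to compound 4 (0.20 log units; that floor lies within the scatter), an expectation resting on no measured step.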

Compound 4, solubility: < 5000 nM
Compound 4: a limit, no number; the forecaster's own chance of this, stated with the estimate: 45%; middle value at least 1.6-fold (0.20 log units) from the limit.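

In this assay compound 4 gives < 5000 nM, which is a limit of the assay and not a number. Its steps from compound 1, compound 2 and compound 3 therefore cannot be read in size or direction: the limit of < 5000 nM in this assay, at which 4 of the 4 values shown sit. As far as these compounds go, how these four compounds, with their methoxy, fluoro, trifluoromethyl and carbamoyl groups, rank against one another in solubility stays open.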